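The source may hold more compounds than are shown below. What is called first, only, known or untested is meant among the compounds shown, and "the series" means these compounds.

Compound 1, `C=C1C[C@]23C[C@@]1(O)CC[C@@H]2c1cccc(C)c1[C@@H]3Cn1cc(-c2ccc(Cl)cc2)nn1`: > 20000 nM
Compound 2, `C=C1C[C@]23C[C@@]1(O)CC[C@H]2c1ccc(OS(=O)(=O)c2ccc(C)cc2)c(C)c1[C@@H]3Cn1cc(-c2ccc(F)cc2)nn1`: > 20000 nM
Compound 3, `C=C1C(=O)[C@]23C[C@@]1(O)CC[C@H]2c1ccc(OS(=O)(=O)c2ccc(C)cc2)c(C)c1[C@@H]3Cn1cc(-c2ccc(C)cc2)nn1`: 320 nM

Of the compounds shown here, three sharing one core have been tested in a functional assay on MCF7 cells (Homo sapiens) for cytotoxicity, read by MTT assay, with a stated time of 4 days; a lower number here means a stronger inhibitor, a higher number a weaker inhibitor. For compound 1 the result is a limit of the assay, > 20000 nM. For compound 2 the result is also a limit, > 20000 nM. Among the compounds with values here, compound 3, which carries a carbonyl where the other two do not, gives 320 nM and so holds the only actual number among the three results; the other two sit at the limit of > 20000 nM in this assay, at which 2 of the 3 values shown sit. Compound 3 therefore stands alone as the one measurable inhibitor in this set, with no comparison of size possible against the two limits.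

Compound 4, `C=C1C(=O)[C@]23C[C@@]1(O)CC[C@H]2c1ccc(OS(=O)(=O)c2ccc(C)cc2)c(C)c1[C@@H]3Cn1cc(-c2ccc(Cl)cc2)nn1`, has not yet been measured. It differs from compound 3 in a single place: chloro in place of methyl on an aromatic carbon. Within the data shown here, no measured pair in this set shows the effect of such a change. The step of a 1.1-fold higher number from compound 3 to compound 4 (0.04 log units; within the scatter) is expected to stay within the usual scatter, with no clear direction. Compound 4 is thus estimated at 350 nM, within a range from 130 nM to 950 nM.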

Compound 4, half-maximal inhibitory concentration: 1440 nM
Compound 4: the middle estimate sits 4.1-fold (0.61 log units) below what was measured; the whole stated range lies below it.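

In this assay, chloro in place of methyl on an aromatic carbon, para to a large group, gives a 4.5-fold higher number from compound 3 to compound 4 (0.65 log units; beyond the scatter). Within the data shown here, this is the first step in the set that differs in one place only, and it shows that the outer position of the 4-methylphenyl group is not indifferent to what it carries, even though methyl and chloro match in the counts of heavy atoms, hydrogen-bond donors and hydrogen-bond acceptors. Nothing shown accounts for the direction or the size of this step.

With only methyl and chloro compared at this position, the compounds shown leave open how a methoxy group, an amine or a carboxylic acid would read there. From the compounds shown here alone, compound 1 and compound 2 each differ from compound 3 and compound 4 in more than one place, so what the carbonyl contributes on its own also stays open.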